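Plasma stability across a shared benzoxazolone core

The source may report more compounds than this note shows. Statements on the series, on what has been measured and on what is new or still open speak of the compounds shown alone.

Three compounds have been measured in an ADME assay on a cell-free system (plasma, Mus musculus) for metabolic stability, read by LC-MS, tested at 2 uM; on this read-out lower numbers stand for a shorter-lived compound and higher numbers for a longer-lived compound:

Compound 1, `CC(C)CNC(=O)n1c(=O)oc2cc(C3CCCCN3C)ccc21`, gives 0.5 h.
Compound 2, `CN1CCC(c2ccc3c(c2)oc(=O)n3C(=O)NCCOCc2ccccc2)CC1`, gives 0.667 h.
Compound 3, `CN1CCN(c2ccc3c(c2)oc(=O)n3C(=O)NCCCCc2ccccc2)CC1=O`, gives 0.333 h.

Compound 3 shows the smallest of the three numbers, but its gap to compound 1 and its gap to compound 2 both lie within the usual scatter of repeated measurements, so none of the three can be called longer- or shorter-lived than another on this evidence.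

Compound 4, `CCN1CCN(c2ccc3c(c2)oc(=O)n3C(=O)NCCCCc2ccccc2)CC1`, has not yet been measured. It differs from compound 3 in one place: 4-ethylpiperazin-1-yl in place of 4-methyl-3-oxopiperazin-1-yl on an aromatic carbon. Nothing is known yet about a single change of this kind in this series, since no two measured compounds differ in just one place. The three measured values sit close together, so the expectation for the step of a 1.2-fold higher number from compound 3 to compound 4 (0.08 log units; within the scatter) is no change beyond the scatter. Compound 4 is therefore estimated at 0.4 h, with a range from 0.2 h to 0.8 h.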

Compound 4, half-life: < 0.0834 h
Compound 4 ended at the assay's limit; the forecaster's own chance of this, stated with the estimate: 5%; middle value at least 4.7-fold (0.68 log units) from the limit.
By their numbers in this assay, from the lowest: compounds 3, 1 and 2 (each within the scatter of the next). At a limit, below all of these: compound 4.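

Among the compounds shown here, replacing 4-methyl-3-oxopiperazin-1-yl with 4-ethylpiperazin-1-yl on an aromatic carbon gives the first single-place comparison, and in this assay it brings an at least 3.9-fold lower number from compound 3 to compound 4 (0.60 log units; beyond the scatter). For the compounds shown here, the group at this place can therefore shift the half-life beyond the scatter, which the earlier compounds, all differing from one another in more than one place, could not show. From the compounds shown here alone, for compound 4, the value < 0.0834 h is a limit of the assay, so the full size of the step stays unknown: the limit of < 0.0834 h in this assay, at which 1 of the 4 values shown sits.

This step combines two differences, the loss of the ring carbonyl and ethyl in place of methyl, and the compounds shown do not separate them. A 4-methylpiperazin-1-yl group at this place, keeping the methyl without the carbonyl, would pull the two apart.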